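Dimethylamino at the chain end: two benzyl-amino amide isomers

This account rests on a few compounds, and the source may have more. Where it says the series, first, only, none or still open, it means among the compounds named here.

Measured compounds and their values in an assay on HEK293 cells for inhibition of Steryl-sulfatase (Homo sapiens), tested at 1 uM; on this read-out lower numbers stand for a weaker effect and higher numbers for a stronger effect at the one concentration tested:
compound 1, `CN(C)CCCN(Cc1ccccc1)c1cccc(C(=O)N2CCc3ccc(OS(N)(=O)=O)cc3C2)c1`, 26%
compound 2, `CCCN(Cc1ccccc1)c1cccc(C(=O)N2CCc3ccc(OS(N)(=O)=O)cc3C2)c1`, 67.4%
compound 3, `CCCN(Cc1ccccc1)c1ccc(C(=O)N2CCc3ccc(OS(N)(=O)=O)cc3C2)cc1`, 94.3%

Compound 3 stands highest of the three, beyond the scatter from both compound 2 and compound 1. The two cores of compound 2 and compound 3 hold the same atoms joined differently; how they differ is not broken down here, so their two values are simply set side by side.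

Within the data shown here, the one change that is measured twice in this set is dimethylamino in place of hydrogen on a saturated chain carbon, three bonds along the chain from a nitrogen on an aromatic ring. From compound 2 to compound 1 this change gives a number 41.4 percentage points lower from compound 2 to compound 1 (beyond the scatter).

Compound 4, `CN(C)CCCN(Cc1ccccc1)c1ccc(C(=O)N2CCc3ccc(OS(N)(=O)=O)cc3C2)cc1`, is not yet measured. Among the measured compounds shown here, it is made from compound 3 by dimethylamino in place of hydrogen on a saturated chain carbon, three bonds along the chain from a nitrogen on an aromatic ring, the same change at the same place as the one from compound 2 to compound 1, on the core of compound 3 instead.

For compound 4 in this assay a drop of similar size is expected, a number 42.3 percentage points lower from compound 3 to compound 4 (beyond the scatter), resting on the earlier step of a number 41.4 percentage points lower from compound 2 to compound 1 (beyond the scatter) and on the higher starting point of compound 3 with 94.3%. For the measured compounds named here, compound 4 is thus estimated at 52%, with a range from 28% to 76%, since only one earlier step of this kind is available and the core differs.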

Compound 4, a percentage reported as inhibition, at one concentration (the size of the read-out at that concentration, not a potency) in the Steryl-sulfatase assay: 61.6%
Compound 4: the middle estimate sits 9.6 percentage points below what was measured; low and high end bracket the measured number.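

In the Steryl-sulfatase assay, compound 3 gives 94.3% and compound 4 gives 61.6%. In the Steryl-sulfatase assay, dimethylamino in place of hydrogen at the chain end gives a number 32.7 percentage points lower from compound 3 to compound 4 (beyond the scatter), so the change that turns propyl into 3-(dimethylamino)propyl lowers the read-out on this core as well. Set beside the earlier step, the two drops cannot be told apart, and in this pair of cores the change carries over with much the same size: the same change on two cores in the Steryl-sulfatase assay, a number 41.4 percentage points lower (beyond the scatter) from compound 2 to compound 1 and a number 32.7 percentage points lower (beyond the scatter) from compound 3 to compound 4, 8.7 percentage points apart, within the scatter of two such steps. Among these compounds, this rests on only two cores and on a read-out at one concentration, so it shows neither a potency shift nor that the step would hold on any other core, and it gives no cause for the drop. In a physicochemical assay for lipophilicity (on this read-out lower numbers stand for lower lipophilicity and higher numbers for higher lipophilicity), compound 3 gives 1.93 and compound 4 gives 1.93. In the physicochemical assay, the same change reads no change at the digits printed from compound 3 to compound 4 (within the scatter), which on its own does not account for the step in the Steryl-sulfatase assay.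

The compounds shown leave open whether the drop belongs to dimethylamino itself or to any group at the chain end, since a cyclic amine such as morpholine, a neutral ether or a carboxylic acid in that place would separate these readings. They also leave open how a shorter 2-(dimethylamino)ethyl or a longer chain carrying the same amine would behave on either core.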